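Adding a benzyl group to a weak glutaramide inhibitor

The source may report more compounds than this note shows. Statements on the series, on what has been measured and on what is new or still open speak of the compounds shown alone.

Of the compounds shown here, three have been tested in a functional assay on Jurkat cells (Homo sapiens) for inhibition; on this read-out higher numbers stand for weaker inhibition and lower numbers for stronger inhibition. Compound 1, `CCCCCCCCCCCCCCC(N)COCc1ccccc1`, gives 3000 nM. Compound 2, `CCCCCCCCCCCCCCC(COCc1ccccc1)NCC`, gives 6000 nM. Compound 3, `CCCCCCCCCCCCCCC(CO)NC(=O)CCCC(=O)O`, gives 24000 nM, the highest of the three numbers, and its distance from compounds 2 and 1 lies beyond the scatter in both cases.

Compound 4, `CCCCCCCCCCCCCCC(COCc1ccccc1)NC(=O)CCCC(=O)O`, differs from compound 3 in one place: benzyl in place of hydrogen on an oxygen on a saturated carbon. For the measured compounds named here, the only measured single step, a 2.0-fold higher number from compound 1 to compound 2 (0.30 log units; within the scatter), concerns a change on the amine nitrogen and is within the scatter, so it says little about a change on the oxygen. Compounds 1 and 2, which carry the benzyl group on that oxygen, show lower numbers than compound 3, but they also differ from it on the nitrogen, so no clean comparison exists.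

Taking the lower numbers of the two benzyl-bearing compounds as a loose guide, compound 4 is expected to give 9000 nM, with a range of 2500 nM to 32000 nM, which would mean an expected step of a 2.7-fold lower number from compound 3 to compound 4 (0.43 log units; beyond the scatter).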

Compound 4, half-maximal inhibitory concentration: > 50000 nM
Compound 4: only a limit was reported; the forecaster's own chance of this, stated with the estimate: 10%; middle value at least 5.5-fold (0.74 log units) from the limit.
By their numbers in this assay, from the lowest: compounds 1 and 2 (each within the scatter of the next); then compound 3. At a limit, above all of these: compound 4.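

In this assay, benzyl in place of hydrogen on an oxygen on a saturated carbon brings an at least 2.0-fold higher number from compound 3 to compound 4 (0.31 log units; beyond the scatter), so here this change goes the wrong way for inhibition. With the benzyl group kept, the group on the amine nitrogen matters a great deal: (3-carboxypropyl)carbonyl brings an at least 8.3-fold higher number from compound 2 to compound 4 (0.92 log units; beyond the scatter) when it replaces ethyl, and an at least 16-fold higher number from compound 1 to compound 4 (1.22 log units; beyond the scatter) when it replaces hydrogen. Compound 4 therefore gives a limit and not a true number: the limit of > 50000 nM in this assay, at which 1 of the 4 values shown sits.

Going by these compounds, how far compound 4 lies past that limit remains open, so each of these steps gives only its smallest possible size. On these data alone, it is also open whether a shorter carboxylic acid chain on the amine nitrogen, or a free amine alongside the hydroxymethyl, would give lower numbers.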